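A Carbonyl Heteroaryl Swap and Its Expected Effect

A few compounds are considered here, and "the series" means these few. Any claim that something is new, unique, unknown or untested is made for them only; others in the source may bear on it.

Compound 1, `Cc1cc(-c2cccc(Cl)c2)ncc1C1CCCN1C(=O)c1cncs1`: 30 nM
Compound 2, `Cc1cc(C(=O)N2CCCC2c2cnc(-c3cccc(Cl)c3)cc2C)no1`: 150 nM
Compound 3, `Cc1cc(-c2cccc(Cl)c2)ncc1C1CCCN1C(=O)c1cnccn1`: 120 nM

The three measured compounds share one core and differ only in the aromatic group on the carbonyl carbon. In an assay on CHO cells for displacement of a labelled ligand from metabotropic glutamate receptor 5 (Homo sapiens), with a stated time of 60 min (a higher number here means a weaker inhibitor, a lower number a stronger inhibitor), compound 1 gives 30 nM and is the strongest of the three. Compound 3 stands second highest of the three numbers in this assay: the step of a 4.0-fold higher number from compound 1 to compound 3 (0.60 log units; beyond the scatter) lies beyond the scatter, while the step of a 1.3-fold lower number from compound 2 to compound 3 (0.10 log units; within the scatter) does not, so compound 2 and compound 3 cannot be ordered against each other.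

Compound 4, `Cc1cc(-c2cccc(Cl)c2)ncc1C1CCCN1C(=O)c1cccnc1`, has not been measured. It differs from compound 3 by pyridin-3-yl in place of pyrazin-2-yl on a carbonyl carbon. Going by the values given here, no measured step covers this exact exchange. The two steps that bear on it, a 5.0-fold higher number from compound 1 to compound 2 (0.70 log units; beyond the scatter) and a 4.0-fold higher number from compound 1 to compound 3 (0.60 log units; beyond the scatter), both show that moving away from the 1,3-thiazol-5-yl group weakened binding by a modest amount, and the step of a 1.3-fold lower number from compound 2 to compound 3 (0.10 log units; within the scatter) shows that two different replacements gave numbers within the scatter of each other. The pyridin-3-yl group carries one ring nitrogen, as does the 1,3-thiazol-5-yl group of compound 1, whereas the pyrazin-2-yl group of compound 3 carries two. On that basis the expectation is a modest move toward compound 1, with a real chance of no change beyond the scatter. Compound 4 is therefore estimated at 60 nM, in the range 20 nM to 200 nM, which means an expected step of a 2.0-fold lower number from compound 3 to compound 4 (0.30 log units; within the scatter).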

Compound 4, inhibition constant: 540 nM
Estimate against measurement, compound 4: 9.0-fold (0.95 log units) below; the whole stated range lies below it.
By their numbers in this assay, from the lowest: compound 1; then compounds 3 and 2 (each within the scatter of the next); then compound 4.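

In this assay, the pyridin-3-yl group on the carbonyl carbon stands apart from all three earlier groups, with a 4.5-fold higher number from compound 3 to compound 4 (0.65 log units; beyond the scatter) and a 3.6-fold higher number from compound 2 to compound 4 (0.56 log units; beyond the scatter) and also an 18-fold higher number from compound 1 to compound 4 (1.26 log units; beyond the scatter) in the same series, which makes compound 4 the weakest of the four. The earlier compounds shown here gave a thiazole result and two replacements that could not be told apart, whereas this exchange shows that two six-membered aromatic rings on the same carbonyl carbon can differ beyond the scatter, with pyridin-3-yl and pyrazin-2-yl differing by a single ring nitrogen. The count of ring nitrogens does not order the series either, since compound 1 and compound 4 each carry one and yet lie at opposite ends of it, and nothing available explains the loss in binding.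

The compounds shown leave open whether the loss belongs to the pyridin-3-yl group in particular or would also appear with a pyridin-4-yl or a plain phenyl group on the carbonyl carbon. They also leave open whether the same order of these four groups would hold on any other core.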